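Chloropyridine to fluoropyridine: a permeability outlook

The source may hold more compounds than are shown below. What is called first, only, known or untested is meant among the compounds shown, and "the series" means these compounds.

Measured compounds:
Compound 1 `Cc1ccc(Oc2ccc3nc(COc4cccc(C(=O)O)c4)n(C)c3n2)cc1` — in an ADME assay for permeability, using PAMPA, with a stated time of 4 h (on this read-out lower numbers stand for lower permeability and higher numbers for higher permeability), compound 1 gives 12.6 10^-6 cm/s
Compound 2 `Cn1c(COc2cccc(C(=O)O)c2)nc2cnc(Oc3ccc(Cl)c(F)c3)cc21` — in this assay compound 2 gives 11.2 10^-6 cm/s
Compound 3 `Cn1c(COc2cccc(C(=O)O)c2)nc2ccc(Oc3ncccc3Cl)cc21` — in this assay compound 3 gives 8.1 10^-6 cm/s

The three compounds share a core, a methylated bicyclic unit carrying an aryloxy substituent and a carboxylic acid bearing phenoxymethyl arm, and differ only in the aryl group on the ether oxygen. In this assay their numbers are close: the gaps from compound 3 to compound 2 and from compound 3 to compound 1 both lie within the usual scatter, so compound 3 cannot be set apart from either of them on these data.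

Compound 4 `Cn1c(COc2cccc(C(=O)O)c2)nc2ccc(Oc3ccc(F)cn3)cc21` is the next member. It differs from compound 3 in one place: 5-fluoropyridin-2-yl in place of 3-chloropyridin-2-yl on an oxygen on an aromatic ring. For the measured compounds named here, nothing in the three measured compounds isolates this kind of exchange, so there is no measured step to lean on. Given how tightly compound 1, compound 2 and compound 3 cluster in this assay despite different aryl groups, the change to compound 4 is expected to produce no step beyond the scatter, in either direction.

On that basis the step from compound 3 to compound 4 in this assay is expected to be a 1.0-fold higher number from compound 3 to compound 4 (0.02 log units; within the scatter). Compound 4 is therefore estimated at 8.5 10^-6 cm/s in this assay, with a range from 5 10^-6 cm/s to 14 10^-6 cm/s.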

Compound 4, apparent permeability: 4.7 10^-6 cm/s
Compound 4: middle estimate off by 1.8-fold (0.26 log units), on the high side, and the stated range ends above it.
By their numbers in this assay, from the lowest: compounds 4, 3, 2 and 1 (each within the scatter of the next, the first and the last beyond it).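

In this assay, for the compounds shown here, 5-fluoropyridin-2-yl in place of 3-chloropyridin-2-yl on an oxygen on an aromatic ring gives a 1.7-fold lower number from compound 3 to compound 4 (0.24 log units; within the scatter) and is the first step here between two compounds that differ in one place. That step lies within the usual scatter, so this single pair does not show that the exchange changes the read-out, although it also cannot exclude a small real effect. The exchange alters both the halogen and its place on the pyridine, and no measurement available here bears on the result or separates those two changes.

Going by these compounds, it remains open whether the halogen or its place on the pyridine matters more, and whether a methoxy group or a nitrile on the same pyridine would give a step beyond the scatter. Going by these compounds alone, it is also open whether the same exchange would give a similar step on the core of compound 1 or of compound 2, since this pair provides only one comparison on one core.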